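A few compounds are considered here, and "the series" means these few. Any claim that something is new, unique, unknown or untested is made for them only; others in the source may bear on it.

Working notes on the series. In a functional assay on BXPC-3 cells (Homo sapiens) for antiproliferative activity, read by MTT assay, with a stated time of 24 h (on this read-out higher numbers stand for weaker inhibition and lower numbers for stronger inhibition), compound 1 (`CCn1c(C(=O)N[C@@H](C)C(=O)OC)ccc1C(CC)(CC)c1ccc(OCS(=O)(=O)c2ccccc2)c(C)c1`) gives 17900 nM and compound 2 (`CCn1c(C(=O)N[C@@H](C)CO)ccc1C(CC)(CC)c1ccc(OCS(=O)(=O)c2ccccc2)c(C)c1`) gives 15300 nM while compound 3 (`CCn1c(C(=O)NCCCO)ccc1C(CC)(CC)c1ccc(OCS(=O)(=O)c2ccccc2)c(C)c1`) gives 26600 nM on this read-out. The gaps from compound 3 to the other two lie within the scatter, so the three stand level.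

Compound 4 (`CCn1c(C(=O)N[C@@H](C)C(=O)O)ccc1C(CC)(CC)c1ccc(OCS(=O)(=O)c2ccccc2)c(C)c1`) carries 1-carboxyethyl in place of 3-hydroxypropyl on an amide-type nitrogen. Two measured steps change the group at this place. These are a 1.5-fold higher number from compound 1 to compound 3 (0.17 log units; within the scatter) and a 1.7-fold higher number from compound 2 to compound 3 (0.24 log units; within the scatter) and neither exceeds the scatter. The change from methoxycarbonyl to hydroxymethyl, a 1.2-fold lower number from compound 1 to compound 2 (0.07 log units; within the scatter) as well, also stays within it. For the measured compounds named here, no measured compound yet holds the free carboxyl group, so the range is kept wide.

The estimated step is a 1.2-fold lower number from compound 3 to compound 4 (0.08 log units; within the scatter) in this assay and no change beyond the scatter is expected. Compound 4 is expected at 22000 nM with an estimated range from 11000 nM to 45000 nM around it.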

Compound 4, half-maximal inhibitory concentration: 20800 nM
Estimate against measurement, compound 4: 1.1-fold (0.02 log units) above, within the range that was stated.
By their numbers in this assay, from the lowest: compounds 2, 1, 4 and 3 (each within the scatter of the next).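

In this assay, the free carboxyl group on the amide-type nitrogen leaves the number level with the other three compounds, whether reached by hydrogen in place of methyl on an oxygen next to a carbonyl group (a 1.2-fold higher number from compound 1 to compound 4 (0.07 log units; within the scatter)) or by carboxy in place of hydroxymethyl (a 1.4-fold higher number from compound 2 to compound 4 (0.13 log units; within the scatter)). Replacing 3-hydroxypropyl with 1-carboxyethyl also stays within the scatter (a 1.3-fold lower number from compound 3 to compound 4 (0.11 log units; within the scatter)), so methyl ester, alcohol and carboxylic acid ends do not separate across these four compounds. No evidence is available that bears on this result.

From the compounds shown here alone, whether an amine, a primary amide or a longer chain at this place would give a step beyond the scatter remains open. Going by these compounds, the effect of the opposite configuration at the defined stereocentre of 1-carboxyethyl also remains open.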